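Aryl swap on the acylhydrazone of compound 1

The source may report more compounds than this note shows. Statements on the series, on what has been measured and on what is new or still open speak of the compounds shown alone.

Compound 1 `COc1ccc(OC)c(/C=N/NC(=O)Nc2ccc(Oc3ccnc(-c4nncn4CCN(C)C)c3)c(F)c2)c1` gives 6400 nM in a functional assay on U-87MG ATCC cells (Homo sapiens) for cytotoxicity, read by MTT assay, with a stated time of 72 h; a higher number here means a weaker inhibitor, a lower number a stronger inhibitor.
Compound 2 `CN(C)CCn1cnnc1-c1cc(Oc2ccc(NC(=O)N/N=C/c3cccc(Br)c3)cc2F)ccn1` gives 830 nM in this assay.
Compound 3 `CN(C)CCn1cnnc1-c1cc(Oc2ccc(NC(=O)N/N=C/c3cccc(Cl)c3Cl)cc2F)ccn1` gives 13200 nM in this assay.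

Compound 1 holds the second-highest number of the three: a 7.7-fold lower number from compound 1 to compound 2 (0.89 log units; beyond the scatter), while a 2.1-fold higher number from compound 1 to compound 3 (0.31 log units; beyond the scatter). Compound 4 `CN(C)CCn1cnnc1-c1cc(Oc2ccc(NC(=O)N/N=C/c3ccc(O)cc3)cc2F)ccn1` differs from compound 1 in one place only: 4-hydroxyphenyl in place of 2,5-dimethoxyphenyl on a carbon with a double bond to nitrogen. Among the compounds with values here, no measured step introduces 4-hydroxyphenyl at this position. Within the data shown here, the steps that bear on it change the same group: a 7.7-fold lower number from compound 1 to compound 2 (0.89 log units; beyond the scatter) was modest and downward, a 2.1-fold higher number from compound 1 to compound 3 (0.31 log units; beyond the scatter) modest and upward, so the series tolerates wide swings there in either direction. Among the measured compounds shown here, with no closer precedent, a modest step downward is expected, a 2.1-fold lower number from compound 1 to compound 4 (0.33 log units; beyond the scatter). Compound 4 is therefore estimated at 3000 nM in this assay, with a range from 800 nM to 12000 nM.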

Compound 4, half-maximal inhibitory concentration: 7750 nM
Beside the measured number, compound 4's estimate is 2.6-fold (0.41 log units) below it, within the range that was stated.
By their numbers in this assay, from the lowest: compound 2; then compounds 1, 4 and 3 (each within the scatter of the next, the first and the last beyond it).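

In this assay, 4-hydroxyphenyl on this carbon with a double bond to nitrogen does not separate from 2,5-dimethoxyphenyl (a 1.2-fold higher number from compound 1 to compound 4 (0.08 log units; within the scatter)) or from 2,3-dichlorophenyl (a 1.7-fold lower number from compound 3 to compound 4 (0.23 log units; within the scatter)), although those two are separated from each other. Only 3-bromophenyl stands clear of it (a 9.3-fold higher number from compound 2 to compound 4 (0.97 log units; beyond the scatter)), so among these four groups compound 2 alone has the lowest number beyond the scatter. No measurement available here accounts for this pattern. Going by these compounds, whether a 4-aminophenyl or a 4-carboxyphenyl group at this place would sit nearer compound 2 or compound 4 stays open.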